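Hydroxy for nitro on the aryl ring of a chalcone

The compounds below may be only part of what the source reports. "The series", "measured", "known", "first", "only" and "open" are said of these compounds alone.

The series shares a chalcone-type core, seen in compound 1 `COc1ccc(C(=O)/C=C/c2cc(OC)c(OC)c(OC)c2)c2c1C=CC(C)(C)O2`, compound 2 `COc1ccc(C(=O)/C=C/c2ccc3ccccc3c2)c2c1C=CC(C)(C)O2` and compound 3 `COc1ccc(C(=O)/C=C/c2ccc([N+](=O)[O-])cc2)c2c1C=CC(C)(C)O2`. In a functional assay on HT-29 cells (Homo sapiens) for antiproliferative activity, read by MTT assay, with a stated time of 24 h (a lower number here means a stronger inhibitor, a higher number a weaker inhibitor), compound 1 reaches only the limit of the measurement, > 10000 nM, and gives no number. In this assay compound 2 gives 4480 nM. In this assay compound 3 gives 3730 nM, which sits alongside the number for compound 2 within the usual scatter, so the two cannot be ranked against each other.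

Compound 4 `COc1ccc(C(=O)/C=C/c2ccc(O)cc2)c2c1C=CC(C)(C)O2` has not yet been measured. It differs from compound 3 in one place: hydroxy in place of nitro on an aromatic carbon. Within the data shown here, no step between two measured compounds isolates this change, so the expectation rests on the general level of the measured numbers rather than on a matching precedent.

Among the measured compounds shown here, because the two numbers in hand for compound 2 and compound 3 lie close together and compound 1 sits at the limit (the limit of > 10000 nM in this assay, at which 1 of the 3 values shown sits), the series so far shows only modest activity. The step from compound 3 to compound 4 is therefore expected to be small, a 1.5-fold higher number from compound 3 to compound 4 (0.17 log units; within the scatter), with a real possibility that compound 4 also falls at the limit. The estimate for compound 4 in this assay is 5500 nM, expected to lie between 1500 nM and 20000 nM.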

Compound 4, half-maximal inhibitory concentration: > 10000 nM
Compound 4 ended at the assay's limit; the forecaster's own chance of this, stated with the estimate: 35%; middle value at least 1.8-fold (0.25 log units) from the limit.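

In this assay, among these compounds, hydroxy in place of nitro on the aromatic carbon para to a large group gives an at least 2.6-fold higher number from compound 3 to compound 4 (0.42 log units; beyond the scatter), the first step that isolates a single change. It shows that this position is not indifferent to what it carries: the 4-nitrophenyl of compound 3 gives a measured number, whereas the 4-hydroxyphenyl of compound 4 does not. With this step, the limit also accounts for more of the series than it did before: the limit of > 10000 nM in this assay, at which 2 of the 4 values shown sit.

Going by these compounds, the step is only a lower bound, so how much weaker compound 4 is than compound 3 remains unknown, and a single pair cannot show which feature of the two groups matters, or whether the same step would hold on a different core. On these data alone, it also remains open whether an amine or a carboxylic acid at this same place would keep a measurable number in this assay or would likewise reach the limit.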